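Swapping Iodo for Amino: Expected Cytotoxicity of Compound 4

The compounds below may be only part of what the source reports. "The series", "measured", "known", "first", "only" and "open" are said of these compounds alone.

Compound 1 `O=C(/C=C/c1ccc2c(c1)B(O)OC2)c1ccc(Cl)c(Cl)c1`: > 10 ug/mL
Compound 2 `O=C(/C=C/c1ccc2c(c1)B(O)OC2)c1ccc(I)cc1`: > 10 ug/mL
Compound 3 `O=C(CCc1ccc2c(c1)B(O)OC2)c1ccccc1`: > 10 ug/mL

In an ADME assay on L929 cells (Mus musculus) for cytotoxicity, read by resazurin assay, with a stated time of 72 h (on this read-out higher numbers stand for weaker inhibition and lower numbers for stronger inhibition), compound 2 gives > 10 ug/mL, which is a limit of the assay rather than a number. Compound 1 likewise sits at a limit. Compound 3 sits at a limit as well. All three values share (the limit of > 10 ug/mL in this assay, at which 3 of the 3 values shown sit), so no order among them can be read. Compound 4 `Nc1ccc(C(=O)/C=C/c2ccc3c(c2)B(O)OC3)cc1` has not yet been measured in this assay; it differs from compound 2 by amino in place of iodo on an aromatic carbon. Among the compounds with values here, no measured pair shows what this change does here. Since every value rests at the limit of > 10 ug/mL in this assay, at which 3 of the 3 values shown sit, a step beyond the scatter is not expected. The step that the limit leaves unreadable from compound 2 to compound 4 is estimated to stay within the scatter. Compound 4 is expected at 15 ug/mL, between 7 ug/mL and 40 ug/mL.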

Compound 4, half-maximal inhibitory concentration: > 10 ug/mL
Compound 4: no number, only a limit; the forecaster's own chance of this, stated with the estimate: 75%; the middle value lies beyond the limit too.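

No step can be read from compound 2 to compound 4, as both values are limits of the assay rather than numbers: the limit of > 10 ug/mL in this assay, at which 4 of the 4 values shown sit.

What amino in place of iodo does in this assay stays open with the compounds shown.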